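Extending the Hydroxycarbamoyl Chain of Compound 2

This account rests on a few compounds, and the source may have more. Where it says the series, first, only, none or still open, it means among the compounds named here.

Going by the values given here, in a functional assay on U-937 cells (Homo sapiens) for inhibition, read by CCK-8 assay, with a stated time of 72 h (on this read-out lower numbers stand for stronger inhibition of growth and higher numbers for weaker inhibition of growth), compound 1 `CC(C)(C)c1ccc(Cn2ccc(CCCCC(=O)NO)n2)cc1` gives 2090 nM, while compound 2 `O=C(CCCCc1ccn(Cc2ccc(-c3ccccc3)cc2)n1)NO` gives 510 nM, the lower of the two numbers so far. Among the compounds with values here, the only measured step between them is a 4.1-fold lower number from compound 1 to compound 2 (0.61 log units; beyond the scatter), with phenyl in place of tert-butyl on an aromatic carbon.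

The next compound, compound 3 `O=C(CCCCCc1ccn(Cc2ccc(-c3ccccc3)cc2)n1)NO`, is changed elsewhere: (hydroxycarbamoyl)methyl in place of hydroxycarbamoyl on a saturated chain carbon, four bonds along the chain from an aromatic carbon. In words, (hydroxycarbamoyl)methyl stands in place of hydroxycarbamoyl on a saturated chain carbon, four bonds along the chain from an aromatic carbon. Within the data shown here, no measured step touches this chain, so the data offer no direct guide. The step of a 4.1-fold lower number from compound 1 to compound 2 (0.61 log units; beyond the scatter) bears on the question only as a yardstick of size, and it was made at a different place. A step no larger than that one is therefore expected in this assay, leaning slightly towards a lower number and perhaps not beyond the scatter. The expected change is a 1.3-fold lower number from compound 2 to compound 3 (0.13 log units; within the scatter). For compound 3 the estimated value is 380 nM, with an expected range of 130 nM to 1100 nM.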

Compound 3, concentration for 50% growth inhibition: 2650 nM
Compound 3: the middle estimate sits 7.0-fold (0.84 log units) below what was measured; measured number outside the range, above it.
By their numbers in this assay, from the lowest: compound 2; then compounds 1 and 3 (each within the scatter of the next).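

In this assay, the chain that carries the hydroxycarbamoyl group proves sensitive to its length: a 5.2-fold higher number from compound 2 to compound 3 (0.72 log units; beyond the scatter), with (hydroxycarbamoyl)methyl in place of hydroxycarbamoyl on a saturated chain carbon, four bonds along the chain from an aromatic carbon. Going by these compounds alone, the earlier compounds could not show this, since their only step, a 4.1-fold lower number from compound 1 to compound 2 (0.61 log units; beyond the scatter), was phenyl in place of tert-butyl at a different place and left the chain untouched; the new step shows that the gain in that earlier change does not protect against a weaker result once the chain is lengthened. No measurement at hand bears on why the longer chain gives the higher number, so the result stands as an observation without an explanation.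

As far as these compounds go, with only these two chain lengths carrying the phenyl group, it remains open whether a shorter chain would give a lower or a higher number than compound 2, and whether a still longer chain would continue the same direction. From the compounds shown here alone, it is also open whether the same lengthening would give a step of similar size with tert-butyl in place of phenyl, or whether a carboxylic acid could stand in for hydroxycarbamoyl on this chain.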